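Lipophilicity shift on replacing the amino-linked side chain

A few compounds are considered here, and "the series" means these few. Any claim that something is new, unique, unknown or untested is made for them only; others in the source may bear on it.

Compound 1 `CCOc1ccccc1-c1ccc(-c2nc3cnccc3c(NC(C(N)=O)C3CC3)c2C#N)cc1`: 3
Compound 2 `CCOc1ccccc1-c1ccc(-c2nc3cnccc3c(N[C@H](CC(C)C)C(N)=O)c2C#N)cc1`: 3.4
Compound 3 `CCOc1ccccc1-c1ccc(-c2nc3cnccc3c(N[C@H](CC)C(=O)NS(=O)(=O)C3CC3)c2C#N)cc1`: 2.3

In a physicochemical assay for lipophilicity, read by HPLC, at pH 7.5 (a higher number here means a more lipophilic compound, a lower number a more polar compound), compound 2 stands highest of the three: a number 0.40 log units higher from compound 1 to compound 2 (beyond the scatter), and a number 1.10 log units lower from compound 2 to compound 3 (beyond the scatter). Compound 4 `CCOc1ccccc1-c1ccc(-c2nc3cnccc3c(C[C@H](C)C(N)=O)c2C#N)cc1` differs from compound 2 in one place: 2-carbamoylpropyl in place of (1-carbamoyl-3-methylbutyl)amino on an aromatic carbon. For the measured compounds named here, none of the measured steps exchanges the amino link for a carbon link, so they bear on this change only loosely. The step from compound 1 to compound 2 was modest, and the large drop to compound 3 came with a quite different group. A smaller change than either is therefore expected here, near or within the scatter: a number 0.20 log units lower from compound 2 to compound 4 (within the scatter). Compound 4 is estimated at 3.2, between 2.7 and 3.7.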

Compound 4, distribution coefficient: 3
Beside the measured number, compound 4's estimate is 0.20 log units above it, and the stated range covers the measured number.
By their numbers in this assay, from the lowest: compound 3; then compounds 1 and 4 (each within the scatter of the next); then compound 2.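

In this assay, for the compounds shown here, the first exchange of the amino link for a carbon link at this aromatic carbon gives a number 0.40 log units lower from compound 2 to compound 4 (beyond the scatter), so this change moves the number beyond the scatter. Against the different amino-linked group of compound 1, the same carbon-linked group gives no change at the digits printed from compound 1 to compound 4 (within the scatter), which shows that the two kinds of link can read alike when the groups differ. No measurement shown accounts for either step. The link and the chain change together here, so their shares stay apart unknown. From the compounds shown here alone, a carbon-linked chain as long as (1-carbamoyl-3-methylbutyl)amino, or a carboxylic acid in place of the amide, remains open.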